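The source may hold more compounds than are shown below. What is called first, only, known or untested is meant among the compounds shown, and "the series" means these compounds.

The measured compounds:

Compound 1, `Cc1ccc(-c2ncccn2)c(C(=O)N2CCC3(CC3)C[C@H]2CNc2ccc(Cl)cn2)c1`. In a functional assay on HEK293 cells for antagonist activity at Orexin receptor type 2 (Homo sapiens), read by FLIPR and calcium flux (a higher number here means a more potent compound, by a factor of ten per unit of this negative logarithm, a lower number a less potent compound), compound 1 gives < 5, which is a limit of the assay and not a number.
Compound 2, `Cc1cc(C)nc(NC[C@@H]2CC3(CC3)CN2C(=O)c2nc(C)sc2-c2ccccc2)n1`. In this assay compound 2 gives 8.6.
Compound 3, `N#Cc1ccc(-c2ncccn2)c(C(=O)N2CC3(CC3)C[C@H]2CNc2ccc(C(F)(F)F)cn2)c1`. In this assay compound 3 gives 8.1.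

Compound 2 holds the highest of the two numbers shown. Its nearest neighbour is compound 3, whose value sits lower by a gap that is beyond the usual scatter of repeated measurements. The result for compound 1 stands apart as a limit: the limit of < 5 in this assay, at which 1 of the 3 values shown sits.

Compound 4, `Cc1nc(C(=O)N2CC3(CC3)C[C@H]2CNc2ccc(C(F)(F)F)cn2)c(-c2ccccc2)s1`, has not yet been measured. It keeps the whole of compound 2 apart from one place: 5-(trifluoromethyl)pyridin-2-yl in place of 4,6-dimethylpyrimidin-2-yl on an amine nitrogen. The entering group is the same one that compound 3 carries on its amine nitrogen, but compound 3 also differs from compound 4 in its core, so the value of compound 3 is only a loose guide.

Among the compounds with values here, no measured pair shows this exact exchange. The step from compound 2 to compound 4 is expected to be small, a modest loss in this assay that may well lie within the scatter: a number 0.30 log units lower from compound 2 to compound 4 (within the scatter). Compound 4 is therefore estimated at 8.3, with a likely range from 7.6 to 9.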

Compound 4, negative logarithm of the antagonist equilibrium constant: 7.7
Beside the measured number, compound 4's estimate is 0.60 log units above it; low and high end bracket the measured number.
By their numbers in this assay, from the lowest: compound 4; then compound 3; then compound 2. At a limit, below all of these: compound 1.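

This is the first pair shown that differs in one place only, and it shows that potency depends on the group on this amine nitrogen: in this assay, 5-(trifluoromethyl)pyridin-2-yl in place of 4,6-dimethylpyrimidin-2-yl gives a number 0.90 log units lower from compound 2 to compound 4 (beyond the scatter) with the rest of the molecule unchanged. Both groups are six-membered aromatic rings, so in this pair keeping that kind of ring on the nitrogen does not preserve the potency. Nothing measured here explains the drop, and the data cannot tell which part of the exchange accounts for it.

The exchange alters the number of ring hetero atoms and the substituents together, so the compounds shown do not separate the two; an unsubstituted pyridin-2-yl or a 5-(trifluoromethyl)pyrimidin-2-yl on the same amine nitrogen would pull them apart in this assay. As far as these compounds go, whether a step of this size would recur with the same exchange on a different amide part also remains open, as this single pair shares one core and one amide group.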